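Halogenated phenyl in place of ethylphenyl on a sulfonamide

This account rests on a few compounds, and the source may have more. Where it says the series, first, only, none or still open, it means among the compounds named here.

Compound 1, `CCc1ccc(S(=O)(=O)N2CCC(N3CCC(C)CC3)CC2)cc1`, gives > 5000 nM in an ADME assay on HCT-116 cells (Homo sapiens) for cytotoxicity, read by CellTiter-Glo, with a stated time of 72 h (on this read-out lower numbers stand for stronger inhibition and higher numbers for weaker inhibition), and this is a limit of the measurement rather than a number. Two further compounds share its core. Compound 2, `COC(=O)c1ccc(S(=O)(=O)N2CCC(N3CCC(C)CC3)CC2)cc1`, gives > 5000 nM, again a limit. Compound 3, `CCCCOc1ccc(S(=O)(=O)N2CCC(N3CCC(C)CC3)CC2)cc1`, gives > 5000 nM, also a limit. The steps among these three are a step that the two limits leave unreadable from compound 1 to compound 2, a step that the two limits leave unreadable from compound 1 to compound 3 and a step that the two limits leave unreadable from compound 2 to compound 3, so none of them can be read, and every known value sits at the limit of > 5000 nM in this assay, at which 3 of the 3 values shown sit. The unmeasured compound 4, `CC1CCN(C2CCN(S(=O)(=O)c3ccc(Br)c(Cl)c3)CC2)CC1`, differs from compound 1 in one place: 4-bromo-3-chlorophenyl in place of 4-ethylphenyl on a sulfonyl sulfur. For the measured compounds named here, no measured step bears on this exchange, and the three known values give no direction, so there is no basis for expecting a step beyond the scatter; the most probable outcome is another limit. Compound 4 is therefore expected to give 8000 nM, with a range from 2500 nM to 30000 nM. The step from compound 1 to compound 4 is estimated as a step that the limit leaves unreadable from compound 1 to compound 4.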

Compound 4, half-maximal inhibitory concentration: > 5000 nM
Compound 4: only a limit was reported; the forecaster's own chance of this, stated with the estimate: 80%; the middle value lies beyond the limit too.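

Compound 4 gives > 5000 nM, a limit of the measurement and not a number, so its step from compound 1, which also has only a limit, cannot be read: the limit of > 5000 nM in this assay, at which 4 of the 4 values shown sit.

The compounds shown leave open whether any change to this phenyl group would give a readable number in this assay.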